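Hydroxy in place of nitro: compound 2 to compound 4

The compounds below may be only part of what the source reports. "The series", "measured", "known", "first", "only" and "open" are said of these compounds alone.

Of the compounds shown here, three have been measured in a functional assay on SW-620 cells (Homo sapiens) for antiproliferative activity, read by MTT assay, with a stated time of 24 h; a lower number here means a stronger inhibitor, a higher number a weaker inhibitor. Compound 1 `COc1cc(OC)c(OC)cc1/C=C/C(=O)c1ccc(OC)c2c1OC(C)(C)C=C2` reaches only the limit of > 10000 nM. Compound 3 `COc1ccc(C(=O)/C=C/c2ccc(C(F)(F)F)cc2)c2c1C=CC(C)(C)O2` likewise sits at the limit of > 10000 nM. For the measured compounds named here, compound 2 `COc1ccc(C(=O)/C=C/c2cccc([N+](=O)[O-])c2)c2c1C=CC(C)(C)O2` gives 4090 nM, the only number among the three. The values of compound 1 and compound 3 are limits (the limit of > 10000 nM in this assay, at which 2 of the 3 values shown sit). Compound 4 `COc1ccc(C(=O)/C=C/c2cccc(O)c2)c2c1C=CC(C)(C)O2` has not yet been measured; it differs from compound 2 by hydroxy in place of nitro on an aromatic carbon. No step between measured compounds is shown, so nothing in the data sets the size or direction of this change. The step from compound 2 to compound 4 is expected to stay within the scatter, leaning if anything toward weaker inhibition, as a 1.3-fold higher number from compound 2 to compound 4 (0.13 log units; within the scatter). Compound 4 is therefore estimated at 5500 nM, within 1800 nM to 16000 nM.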

Compound 4, half-maximal inhibitory concentration: > 10000 nM
Compound 4 ended at the assay's limit (the forecaster's own chance of this, stated with the estimate: 30%); at least 1.8-fold (0.25 log units) between middle value and limit.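

Hydroxy in place of nitro on an aromatic carbon gives an at least 2.4-fold higher number from compound 2 to compound 4 (0.38 log units; beyond the scatter), the first step read in this assay, and it runs toward weaker inhibition. At this place, then, the nitro of compound 2 does not tolerate exchange for hydroxy without loss. The step is only a bound, since the value of compound 4 is a limit: the limit of > 10000 nM in this assay, at which 3 of the 4 values shown sit.

On these data alone, how far compound 4 lies past that limit, and so the true size of the step, stays open. As far as these compounds go, whether an amine or a carboxylic acid at the same place would return a number is also open.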